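The compounds below may be only part of what the source reports. "The series", "measured", "known", "first", "only" and "open" are said of these compounds alone.

Compound 2 `Cc1cc(C)c(-c2cccnc2)cc1NC(=O)c1ccc(OCc2ccccn2)cc1` is the starting point. In a physicochemical assay for lipophilicity (on this read-out lower numbers stand for lower lipophilicity and higher numbers for higher lipophilicity), compound 2 gives > 3, which is a limit of the assay and not a number. Among the measured compounds shown here, the only other measured compound is compound 1 `Cc1cc(C)c(-c2nc3ccccc3[nH]2)cc1NC(=O)c1ccc(OCc2ccccn2)cc1`. In this assay compound 1 gives > 3.5, again a limit and not a number. For the measured compounds named here, the one measured step, a step that the two limits leave unreadable from compound 1 to compound 2, cannot be read in size, since compound 1 sits at the limit of > 3.5 in this assay, at which 1 of the 2 values shown sits, and compound 2 at the limit of > 3 in this assay, at which 1 of the 2 values shown sits. Compound 3 `Cc1cc(C)c(-c2cccc(N)n2)cc1NC(=O)c1ccc(OCc2ccccn2)cc1` differs from compound 2 in one place: 6-aminopyridin-2-yl in place of pyridin-3-yl on an aromatic carbon. Going by the values given here, no measured step shows what this change does in this assay, so the only anchor is the limit reached by compound 2. Compound 3 is therefore expected to move from compound 2 by a step that the limit leaves unreadable from compound 2 to compound 3, a step not beyond the usual scatter. The estimate for compound 3 in this assay is 3.3, with a range from 2.6 to 4.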

Compound 3, distribution coefficient: > 3
Compound 3 ended at the assay's limit; the forecaster's own chance of this, stated with the estimate: 45%; the middle value lies beyond the limit too.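

In this assay compound 3 gives > 3, which is a limit and not a number. The steps to compound 3 from compound 2 and from compound 1 therefore cannot be read in size. The compounds shown leave open the actual distribution coefficient of all three compounds and whether these group changes shift it at all.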